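A few compounds are considered here, and "the series" means these few. Any claim that something is new, unique, unknown or untested is made for them only; others in the source may bear on it.

Compound 1 `COc1c(Oc2ccnc(Nc3ccc(C#N)cc3)n2)ccc2cc(C#N)ccc12` gives > 211000 nM, which is a limit of the assay and not a number.
Compound 2 `COc1cc2cc(C#N)ccc2c(OC)c1Oc1ccnc(Nc2ccc(C#N)cc2)n1` gives > 118000 nM, which is also a limit of the assay.
Compound 3 `N#Cc1ccc(Nc2nccc(Oc3ccc4cc(C#N)ccc4c3Cl)n2)cc1` gives 269000 nM.

Among the compounds with values here, in an ADME assay on MT4 cells (Homo sapiens) for cytotoxicity, read by MTT assay, with a stated time of 4 days (on this read-out higher numbers stand for lower toxicity in this test and lower numbers for higher toxicity in this test), compound 3 is the only one with a number. The change from compound 1 to compound 2 is methoxy in place of hydrogen on an aromatic carbon; its step is a step that the two limits leave unreadable from compound 1 to compound 2. The two cores differ by chloro in place of methoxy on an aromatic carbon, with the step that the limit leaves unreadable from compound 1 to compound 3. Compound 4 `COc1cc2cc(C#N)ccc2c(Cl)c1Oc1ccnc(Nc2ccc(C#N)cc2)n1` is not yet measured and differs from compound 3 by methoxy in place of hydrogen on an aromatic carbon. The place is not the same as before: in compound 2 the methoxy enters meta to a methoxy group, in compound 4 meta to a chloro group, so this is the same kind of change, not the same. A step of a 1.1-fold lower number from compound 3 to compound 4 (0.03 log units; within the scatter) is expected, resting on compound 3 with 269000 nM and on the unreadable earlier step that the two limits leave unreadable from compound 1 to compound 2. For compound 4 the expected value in this assay is 250000 nM, estimated between 120000 nM and 500000 nM.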

Compound 4, half-maximal cytotoxic concentration: > 190000 nM
Compound 4: a limit, no number (the forecaster's own chance of this, stated with the estimate: 50%); the middle value lies beyond the limit too.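

Compound 4 gives a limit of the assay and not a number, and its steps from compound 3 and from compound 2 cannot be read. The compounds shown leave open how much methoxy in place of hydrogen, or chloro in place of methoxy, changes the read-out in this assay.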